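Working notes: aryl for cyclohexyl on a ring amine nitrogen

A few compounds are considered here, and "the series" means these few. Any claim that something is new, unique, unknown or untested is made for them only; others in the source may bear on it.

Of the compounds shown here, two carry numbers so far. In an ADME assay on HeLa cells (Homo sapiens) for cytotoxicity, read by MTT assay, with a stated time of 48 h, tested at 50 uM (on this read-out higher numbers stand for a weaker effect at the one concentration tested and lower numbers for a stronger effect), compound 1 `Cc1ccc(CN(C)CCCCn2nc(-c3ccccc3)oc2=O)c(C)c1` gives 80%. In this assay compound 2 `O=C1CCc2ccccc2N1CCCCN1CCN(C2CCCCC2)CC1` gives 79%, the lowest of the two numbers, though its nearest neighbour, compound 1, sits within the scatter of it, so the two cannot be ordered. Both read as weak effects at the single concentration.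

Compound 3 `O=C1CCc2ccccc2N1CCCCN1CCN(c2ccc(F)cc2)CC1` is not yet measured. It differs from compound 2 in one place: 4-fluorophenyl in place of cyclohexyl on an amine nitrogen in a ring. Among the measured compounds shown here, no step between measured compounds that differ in one place is available, so nothing on record tells how this kind of change moves the read-out. The expectation therefore rests on the two measured numbers lying close together, and a step of a number 1 percentage points lower from compound 2 to compound 3 (within the scatter) of no size beyond the scatter is expected. Compound 3 is expected to give 78%, with a range from 60% to 95%.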

Compound 3, a percentage reported as activity, at one concentration (the size of the read-out at that concentration, not a potency): 70%
Compound 3: the middle estimate sits 8 percentage points above what was measured; the measured number falls inside the stated range.
By their numbers in this assay, from the lowest: compounds 3, 2 and 1 (each within the scatter of the next).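

Among the compounds shown here, the first step at this position, 4-fluorophenyl in place of cyclohexyl on an amine nitrogen in a ring, gives in this assay a number 9 percentage points lower from compound 2 to compound 3 (within the scatter). An aromatic ring carrying fluorine and a non-aromatic ring of carbon only therefore cannot be told apart on this read-out, and this single pair shows no effect of the change beyond the usual scatter. Nothing on record bears on why the step has this size.

Still open, as far as these compounds go, is whether the fluorine has any part in the step, which plain phenyl or 4-methoxyphenyl on the same ring nitrogen would address. Also open, from the compounds shown here alone, is whether any group at this nitrogen, such as a carboxylic acid on the aryl ring or a basic amine on a longer chain, would move the read-out beyond the scatter.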